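The compounds below may be only part of what the source reports. "The series", "measured", "known", "first", "only" and "open" are said of these compounds alone.

Three compounds have been measured in an assay on HEK293 cells for agonist activity at Toll-like receptor 8 (Homo sapiens), read by a luciferase reporter, with a stated time of 6 h; on this read-out higher numbers stand for an effect only at larger amounts of compound and lower numbers for an effect already at smaller amounts:

compound 1, `CCCCNc1nc(N)nc2c1CNCC2`, gives 7.2 uM
compound 2, `CCCCNc1nc(N)nc2c1CN(C)CC2`, gives 0.03 uM
compound 3, `CCCCNc1nc(N)nc2c1CN(C(=O)c1ccccc1)CC2`, gives 1.4 uM

Compound 2 has the lowest number of the three, and both of its steps to the others lie beyond the scatter: a 47-fold higher number from compound 2 to compound 3 (1.67 log units; beyond the scatter) and, going the other way, a 240-fold lower number from compound 1 to compound 2 (2.38 log units; beyond the scatter). The unmeasured compound 4, `CCCCNc1nc(N)nc2c1CN(Cc1cccc(Cl)c1Cl)CC2`, differs from compound 2 in one place: 2,3-dichlorophenyl in place of hydrogen on a saturated chain carbon bound to an amine nitrogen in a ring. Going by the values given here, no measured step makes this same change. What the measured steps show is that the group on the ring nitrogen matters a great deal in this assay: a methyl in place of hydrogen gave a 240-fold lower number from compound 1 to compound 2 (2.38 log units; beyond the scatter), a benzoyl in place of hydrogen gave the smaller 5.1-fold lower number from compound 1 to compound 3 (0.71 log units; beyond the scatter), and the exchange of methyl for benzoyl gave a 47-fold higher number from compound 2 to compound 3 (1.67 log units; beyond the scatter). Compound 4 keeps a saturated carbon on the ring nitrogen, as compound 2 does, so the expectation is a modest step, most likely upward, namely a 3.3-fold higher number from compound 2 to compound 4 (0.52 log units; beyond the scatter). Compound 4 is therefore estimated at 0.1 uM, within a range of 0.02 uM to 1 uM.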

Compound 4, minimum effective concentration: 0.18 uM
The estimate for compound 4 lay 1.8-fold (0.26 log units) below the measured number; measured number inside the range.
By their numbers in this assay, from the lowest: compound 2; then compound 4; then compound 3; then compound 1.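

Compound 4 shows that the saturated chain carbon bound to the ring's amine nitrogen can carry far more than hydrogen: in this assay adding 2,3-dichlorophenyl, with its 8 heavy atoms, gives a 6.0-fold higher number from compound 2 to compound 4 (0.78 log units; beyond the scatter) and still only a modest step. That step is much smaller than a 47-fold higher number from compound 2 to compound 3 (1.67 log units; beyond the scatter) when benzoyl replaces methyl, so a large group on the ring nitrogen does not by itself bring a large rise in the number. Compounds 3 and 4 differ in more than one place, however, so the carbonyl of compound 3 cannot be singled out. The compounds shown leave open how much of the step comes from the ring and how much from its two chlorines, which a plain benzyl group would address. They also leave open how a longer chain or a chain ending in an amine would fare here, and no measurement on hand explains the step.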